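A few compounds are considered here, and "the series" means these few. Any claim that something is new, unique, unknown or untested is made for them only; others in the source may bear on it.

The compounds measured so far:

Compound 1, `O=C(Nc1ccc(-n2ccc3nc(C(=O)NCc4ccccc4)ccc32)cc1)c1cccc(C(F)(F)F)c1` — in an ADME assay on HS27 cells (Homo sapiens) for cytotoxicity, read by MTT assay (on this read-out higher numbers stand for weaker inhibition and lower numbers for stronger inhibition), compound 1 gives only a limit of the assay, > 10000 nM.
Compound 2, `COC(=O)c1ccc2c(ccn2-c2ccc(NC(=O)Nc3ccc(Cl)c(Cl)c3)cc2)n1` — in this assay compound 2 gives 2800 nM.
Compound 3, `NC(=O)c1ccc2c(ccn2-c2ccc(NC(=O)Nc3ccc(Cl)c(Cl)c3)cc2)n1` — in this assay compound 3 gives 6600 nM.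

Compound 2 stands lowest of the two numbers; its nearest neighbour is compound 3, reached by a 2.4-fold higher number from compound 2 to compound 3 (0.37 log units; beyond the scatter), a modest change at the carbonyl carbon. Compound 4, `COC(=O)c1ccc2c(ccn2-c2ccc(NC(=O)Nc3ccc(Cl)c(C(F)(F)F)c3)cc2)n1`, differs from compound 2 elsewhere: trifluoromethyl in place of chloro on an aromatic carbon. Among the measured compounds shown here, no measured step touches that aryl ring, so the one step known gives no guidance for this change, and no shift beyond the scatter is expected. For compound 4 the expected value in this assay is 2800 nM, between 1200 nM and 7000 nM. This amounts to an expected step of no change at the digits printed from compound 2 to compound 4 (within the scatter).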

Compound 4, half-maximal inhibitory concentration: 8200 nM
Compound 4: the middle estimate sits 2.9-fold (0.47 log units) below what was measured, and the stated range ends below it.
By their numbers in this assay, from the lowest: compound 2; then compounds 3 and 4 (each within the scatter of the next). At a limit, above all of these: compound 1.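

In this assay, the change from 3,4-dichlorophenyl to 4-chloro-3-(trifluoromethyl)phenyl gives a 2.9-fold higher number from compound 2 to compound 4 (0.47 log units; beyond the scatter), so this aryl ring, untouched by the earlier step, also moves the number. Compound 2 keeps the lowest number, and single changes at two separate places on it both give higher ones. Compound 1 gives no number but a limit of the assay: the limit of > 10000 nM in this assay, at which 1 of the 4 values shown sits.

The compounds shown leave open how a methyl, a methoxy or a fluoro group on this aromatic carbon would read. They also leave open how trifluoromethyl here and the amino change at the carbonyl carbon would read together on one compound.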